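This account rests on a few compounds, and the source may have more. Where it says the series, first, only, none or still open, it means among the compounds named here.

Measured so far in an ADME assay on SK-OV-3 cells (Homo sapiens) for cytotoxicity, read by sulforhodamine B assay, with a stated time of 48 h, tested at 10 uM; on this read-out higher numbers stand for more inhibition at the one concentration tested (going by the name of the read-out) and lower numbers for less inhibition:

compound 1, `COc1nc2ccc(Br)cc2cc1C(c1ccccc1)n1cc(-c2ccccc2)nn1`: 13.7%
compound 2, `COc1nc2ccc(Br)cc2cc1C(c1ccccc1)n1cc(-c2ccc(OC(F)(F)F)cc2)nn1`: 14.8%

Compound 2 stands highest of the two numbers; its nearest neighbour is compound 1, and the step of a number 1.1 percentage points higher from compound 1 to compound 2 (within the scatter) lies within the scatter, so no order between the two can be claimed. Compound 3, `COc1nc2ccc(Br)cc2cc1C(c1ccccc1)n1cc(CCO)nn1`, is not yet measured in this assay. Relative to compound 2 the change is 2-hydroxyethyl in place of 4-(trifluoromethoxy)phenyl on an aromatic carbon. Among the measured compounds shown here, the only measured step, a number 1.1 percentage points higher from compound 1 to compound 2 (within the scatter), concerns a change on the 4-(trifluoromethoxy)phenyl group that here leaves entirely, and it was within the scatter; no measured step covers the loss of that ring or the entry of 2-hydroxyethyl. Both measured numbers are low. With nothing pointing otherwise, compound 3 is expected to stay near them, the step of a number 2.8 percentage points lower from compound 2 to compound 3 (within the scatter) expected within the scatter. Compound 3 is estimated at 12%, with a range from 2% to 28%.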

Compound 3, a percentage reported as inhibition, at one concentration (the size of the read-out at that concentration, not a potency): 8.46%
The estimate for compound 3 lay 3.5 percentage points above the measured number; measured number inside the range.
By their numbers in this assay, from the lowest: compounds 3, 1 and 2 (each within the scatter of the next).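

Among the compounds shown here, at this position, on an aromatic carbon of the five-membered aromatic ring with 3 nitrogen, the earlier compounds differed only by a substituent on the phenyl ring, whereas compound 3 loses that ring altogether. In this assay this exchange gives a number 6.3 percentage points lower from compound 2 to compound 3 (within the scatter) and, against the unsubstituted phenyl, a number 5.2 percentage points lower from compound 1 to compound 3 (within the scatter), so 2-hydroxyethyl cannot be told apart from either aromatic group on this read-out. No supporting data bear on this result.

From the compounds shown here alone, whether an amine, a carboxylic acid or a longer chain at this position would give a number beyond the scatter stays open. With all three numbers low at the one concentration tested, the compounds shown also leave open which group here, if any, gives substantial inhibition.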